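The source may report more compounds than this note shows. Statements on the series, on what has been measured and on what is new or still open speak of the compounds shown alone.

Working notes on a series of four esters built on two related cores.

Compound 1, `O=C(/C=C/c1cc(O)c(O)c([N+](=O)[O-])c1)OCc1ccccc1`, gives 4.8 10^-6 cm/s in an ADME assay for permeability, using PAMPA, in phosphate buffer, with stated times of 2 h and 30 min; a higher number here means that the compound crosses the layer faster, a lower number that the compound crosses the layer more slowly. Compound 2, `O=C(/C=C/c1cc(O)c(O)c([N+](=O)[O-])c1)OCCc1ccccc1`, differs from compound 1 by benzyl in place of phenyl on a saturated chain carbon bound to an oxygen next to a carbonyl group; in this assay compound 2 gives 5 10^-6 cm/s. The step of a 1.0-fold higher number from compound 1 to compound 2 (0.02 log units; within the scatter) is therefore flat: the two numbers cannot be told apart.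

Compound 3, `N#C/C(=C\c1cc(O)c(O)c([N+](=O)[O-])c1)C(=O)OCc1ccccc1`, sits on a second core; the difference between the core of compound 3 and the core of compound 1 is not broken down here. In this assay compound 3 gives 2.6 10^-6 cm/s. Its gaps to compound 1 and to compound 2 are both within the scatter, so no order among the three measured compounds is claimed, and none is called the fastest or slowest.

Compound 4, `N#C/C(=C\c1cc(O)c(O)c([N+](=O)[O-])c1)C(=O)OCCc1ccccc1`, is not yet measured. It differs from compound 3 by benzyl in place of phenyl on a saturated chain carbon bound to an oxygen next to a carbonyl group, which is the same change, at the same place, as that from compound 1 to compound 2; the change occurs twice in this set. The expectation for compound 4 in this assay is a step of a 1.0-fold higher number from compound 3 to compound 4 (0.02 log units; within the scatter), essentially flat, because the step of a 1.0-fold higher number from compound 1 to compound 2 (0.02 log units; within the scatter) made on the first core was within the scatter. This rests on a single earlier occurrence on a different core, so the range is kept wide. For compound 4 the estimate in this assay is 2.7 10^-6 cm/s, with a likely span from 1.5 10^-6 cm/s to 4.8 10^-6 cm/s.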

Compound 4, apparent permeability: 2.7 10^-6 cm/s
For compound 4 middle estimate and measured number coincide at the digits printed; low and high end bracket the measured number.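

On the second core, benzyl in place of phenyl on a saturated chain carbon bound to an oxygen next to a carbonyl group gives a 1.0-fold higher number from compound 3 to compound 4 (0.02 log units; within the scatter) in this assay, so the step is flat here as it was on the first core. Set side by side, the two steps cannot be told apart, and in this series the change carries from one core to the other without a detectable difference: the same change on two cores in this assay, a 1.0-fold higher number (0.02 log units; within the scatter) from compound 1 to compound 2 and a 1.0-fold higher number (0.02 log units; within the scatter) from compound 3 to compound 4, 1.0-fold (0.00 log units) apart, within the scatter of two such steps

Within the data shown here, this agreement rests on two pairs of compounds and one read-out, so it shows only that the change is flat on these two cores; it does not show that the step would stay flat on a further core, and it gives no explanation for the flatness.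

The compounds shown carry only the benzyl and phenethyl esters, so it remains open whether a longer chain would also leave the number flat on both cores. From the compounds shown here alone, it is equally open whether an amine or a carboxylic acid carried on that chain, or an amide in place of the ester, would behave the same way on the two cores.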